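The compounds below may be only part of what the source reports. "The series", "measured", "known", "first", "only" and "open" are said of these compounds alone.

Three compounds sharing one core have been compared in an assay on cells for activation of probable G-protein coupled receptor 34 (Mus musculus), with a stated time of 1 h; a lower number here means a smaller maximal response, a higher number a larger maximal response. Compound 1 `N[C@@H](COP(=O)(O)OCCCOC(=O)CCc1ccccc1OCc1cccc(Cc2ccccc2)c1)C(=O)O` gives 0.077. Compound 2 `Cc1ccccc1Oc1cccc(COc2ccccc2CCC(=O)OCCCOP(=O)(O)OC[C@H](N)C(=O)O)c1` gives 0.28. Compound 3 `N[C@@H](COP(=O)(O)OCCCOC(=O)CCc1ccccc1OCc1cccc(Oc2cccc(Cl)c2)c1)C(=O)O` gives 0.53, the highest of the three numbers, with compound 2 nearest to it and compound 1 furthest from it.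

Two changes at the same aromatic carbon raised the response: the step a number 0.20 higher from compound 1 to compound 2 (beyond the scatter) came with 2-methylphenoxy in place of benzyl, and the larger step a number 0.45 higher from compound 1 to compound 3 (beyond the scatter) came with 3-chlorophenoxy in place of benzyl. Exchanging the group on the oxygen of that ring, 3-chlorophenyl in place of 2-methylphenyl, gave the step a number 0.25 higher from compound 2 to compound 3 (beyond the scatter).

Compound 4 `N[C@@H](COP(=O)(O)OCCCOC(=O)CCc1ccccc1OCc1cccc(Oc2ccc(Cl)cc2)c1)C(=O)O` is next. Its difference from compound 3 is 4-chlorophenyl in place of 3-chlorophenyl on an oxygen on an aromatic ring. Among the compounds with values here, no measured step exchanges one chlorophenyl for another; the step a number 0.25 higher from compound 2 to compound 3 (beyond the scatter) is the only one at the same oxygen, and it involved a different pair of groups. The change is therefore expected to give a small step, most likely downward or none beyond the scatter. Compound 4 is estimated at 0.45, between 0.25 and 0.65. That corresponds to an expected step of a number 0.080 lower from compound 3 to compound 4 (within the scatter).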

Compound 4, intrinsic activity: the largest response reached, as a fraction of the reference agonist's: 0.76
Beside the measured number, compound 4's estimate is 0.31 below it, outside the stated range (above it).
By their numbers in this assay, from the lowest: compound 1; then compound 2; then compound 3; then compound 4.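

In this assay the exchange of 3-chlorophenyl for 4-chlorophenyl on an oxygen on an aromatic ring gives a result a number 0.23 higher from compound 3 to compound 4 (beyond the scatter) even though both groups contain the same atoms, so at this position the way those atoms are joined matters, not only which atoms are present. The exchange of 2-methylphenyl for 4-chlorophenyl at the same oxygen gives a result a number 0.48 higher from compound 2 to compound 4 (beyond the scatter) and the exchange of benzyl for 4-chlorophenoxy gives a result a number 0.68 higher from compound 1 to compound 4 (beyond the scatter) and leaves compound 4 with the largest maximal response of the four compounds. Nothing measured here accounts for the difference between the two chlorophenyl groups.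

The compounds shown leave open whether the chlorine itself is needed, which 4-fluorophenyl or 4-methylphenyl on the same oxygen could test, and how 2-chlorophenyl would compare with the other two chlorophenyl groups. They also leave open how much the oxygen contributes once the chlorine is in this arrangement, a question that 4-chlorobenzyl in place of 4-chlorophenoxy could address.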